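The source may hold more compounds than are shown below. What is called first, only, known or untested is meant among the compounds shown, and "the series" means these compounds.

Measured compounds:
compound 1, `COc1ccc(CNc2cc(OC)c(OC)c(OC)c2)cc1Cl`, in a functional assay on KYSE-450 cells (Homo sapiens) for inhibition, read by MTT assay, with a stated time of 48 h (a lower number here means a stronger inhibitor, a higher number a weaker inhibitor), compound 1 gives 47800 nM
compound 2, `COC(=O)c1cc(CNc2cc(OC)c(OC)c(OC)c2)ccc1OC`, compound 2 gives 41100 nM
compound 3, `C/C=C/C(=O)N(Cc1ccc(OC)c(N)c1)c1cc(OC)c(OC)c(OC)c1`, compound 3 gives 310 nM

Compound 3 gives the lowest number of the three. Compound 2 stands nearest to it and compound 1 furthest, and both gaps lie beyond the scatter. For the measured compounds named here, the one measured step, a 1.2-fold lower number from compound 1 to compound 2 (0.07 log units; within the scatter), lies within the scatter and concerns a substituent on a different ring from the one altered here; it bears only weakly on the present step.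

Compound 4, `C/C=C/C(=O)N(Cc1ccc(OC)c(O)c1)c1cc(OC)c(OC)c(OC)c1`, differs from compound 3 in one place: hydroxy in place of amino on an aromatic carbon. The exchange swaps one heavy atom for another, keeps one hydrogen-bond donor and one hydrogen-bond acceptor, and leaves the rest of compound 3 unchanged. Going by the values given here, no measured pair carries this kind of change, and the single measured step gives no direction to lean on. The expectation for this assay is a step of about a 1.3-fold higher number from compound 3 to compound 4 (0.11 log units; within the scatter), none beyond the scatter, with the range left wide to allow for either direction. Compound 4 is estimated at 400 nM, expected between 120 nM and 1500 nM.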

Compound 4, half-maximal inhibitory concentration: 67 nM
Estimate against measurement, compound 4: 6.0-fold (0.78 log units) above, and the stated range ends above it.
By their numbers in this assay, from the lowest: compound 4; then compound 3; then compounds 2 and 1 (each within the scatter of the next).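

In this assay, the change from 3-amino-4-methoxyphenyl to 3-hydroxy-4-methoxyphenyl gives a 4.6-fold lower number from compound 3 to compound 4 (0.67 log units; beyond the scatter), so this position, ortho to a methoxy group, is not indifferent to which of the two groups it carries, although the counts of heavy atoms, donors and acceptors stay the same. For the compounds shown here, the earlier step, a 1.2-fold lower number from compound 1 to compound 2 (0.07 log units; within the scatter), stayed within the scatter, which makes this the first single change to move the number beyond the scatter. No measurement at hand accounts for the difference between hydroxy and amino here.

Still open, on these data alone, is whether hydroxy itself matters or only the loss of amino: a fluorine, a methyl group, a hydroxymethyl group or a methoxy group at this position would help to separate the two. Also open, as far as these compounds go, is whether the same exchange holds on a compound with a longer chain on the amide carbonyl, or on a compound of the secondary amine type seen in compound 1 and compound 2.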